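This account rests on a few compounds, and the source may have more. Where it says the series, first, only, none or still open, it means among the compounds named here.

Working notes on the series, which shares one core and differs at the aryl group on the exocyclic double bond.

Three compounds have numbers in a functional assay on ECa-109 cells (Homo sapiens) for cytotoxicity, read by MTT assay, with a stated time of 72 h; on this read-out higher numbers stand for weaker inhibition and lower numbers for stronger inhibition. Compound 1 `COc1cc(C=C2C(=O)N(c3ccc(Cl)cc3)N(c3ccc(Cl)cc3)C2=O)cc(OC)c1OC` gives 10100 nM in this assay. Compound 2 `COc1cc(C=C2C(=O)N(c3ccc(Cl)cc3)N(c3ccc(Cl)cc3)C2=O)ccc1O` gives 7100 nM in this assay. Compound 3 `CC(=C1C(=O)N(c2ccc(Cl)cc2)N(c2ccc(Cl)cc2)C1=O)c1ccc(O)cc1` gives 55600 nM in this assay. Compound 2 has the lowest of the three numbers; compound 1 sits within the scatter of it, so no order between them can be read, while compound 3 sits well beyond the scatter at a higher number.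

Compound 4 `O=C1C(=Cc2ccc(F)cc2F)C(=O)N(c2ccc(Cl)cc2)N1c1ccc(Cl)cc1` has not yet been measured. It differs from compound 2 as follows: 2,4-difluorophenyl in place of 4-hydroxy-3-methoxyphenyl on a double-bonded chain carbon bound to a double-bonded ring carbon. Within the data shown here, no measured pair in this set shows this change, and no pair shows removal of the hydroxyl and methoxy together, so the direction of the step has to be a guess. With the aryl group stripped of both donor and acceptors, the number is expected to move upward by a modest step, a 2.1-fold higher number from compound 2 to compound 4 (0.32 log units; beyond the scatter), though a step inside the scatter cannot be ruled out. Compound 4 is estimated at 15000 nM in this assay, with a range from 5000 nM to 50000 nM.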

Compound 4, half-maximal inhibitory concentration: 13100 nM
Compound 4: middle estimate off by 1.1-fold (0.06 log units), on the high side; low and high end bracket the measured number.
By their numbers in this assay, from the lowest: compounds 2, 1 and 4 (each within the scatter of the next); then compound 3.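

Among these compounds, the step in this assay is a 1.8-fold higher number from compound 2 to compound 4 (0.27 log units; within the scatter), the first one-place step, so 2,4-difluorophenyl in place of 4-hydroxy-3-methoxyphenyl on a double-bonded chain carbon bound to a double-bonded ring carbon gives no change that can be read. In this pair, an aryl group with 0 hydrogen-bond donors and 0 hydrogen-bond acceptors cannot be told apart from the one carrying the hydroxyl and methoxy. No measurement shown here gives a reason for this result.

On these data alone, what a fluorine at only one of the two places would give stays open, as does the outcome with an amine or a carboxylic acid on the aryl group. Compound 3 differs from the others in more than one place, so the methyl on its chain carbon cannot be judged alone.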